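A few compounds are considered here, and "the series" means these few. Any claim that something is new, unique, unknown or untested is made for them only; others in the source may bear on it.

Series notes on the tetrahydroisoquinoline-type amides carrying a sulfamate, read in an assay on HEK293 cells for inhibition of Steryl-sulfatase (Homo sapiens), tested at 1 uM; a higher number here means a stronger effect of the compound at the concentration tested, a lower number a weaker effect. Two members have numbers. Compound 1 `CN(C)CCN(Cc1ccccc1)c1cccc(C(=O)N2CCc3ccc(OS(N)(=O)=O)cc3C2)c1` gives 28.6%. Compound 2 `CN(C)CCN(CCN(C)C)c1cccc(C(=O)N2CCc3ccc(OS(N)(=O)=O)cc3C2)c1` gives 17.1%. Among the measured compounds shown here, the one step so far, a number 11.5 percentage points lower from compound 1 to compound 2 (beyond the scatter), is the only guide available, and compound 2 stands at the lower of the two numbers, with compound 1 a step above it.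

Compound 3 `CN(CCN1CCCCC1)c1cccc(C(=O)N2CCc3ccc(OS(N)(=O)=O)cc3C2)c1` has not been measured. It differs from compound 2 in that (methyl(2-(piperidin-1-yl)ethyl)amino in place of bis(2-(dimethylamino)ethyl)amino on an aromatic carbon). For the measured compounds named here, the measured step from compound 1 to compound 2 bears on it only loosely: that step exchanged one substituent on the aromatic-ring nitrogen, whereas here both substituents on that nitrogen are altered at once, and no measured pair shows a methyl(2-(piperidin-1-yl)ethyl)amino group. Going by the values given here, with a single modest reference step and no direct precedent, the expectation is a step from compound 2 to compound 3 of a number 4.9 percentage points higher from compound 2 to compound 3 (within the scatter), that is, nothing clearly beyond the scatter in either direction. Compound 3 is therefore estimated at 22%, with a range of 8% to 38%.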

Compound 3, a percentage reported as inhibition, at one concentration (the size of the read-out at that concentration, not a potency): 30.8%
Beside the measured number, compound 3's estimate is 8.8 percentage points below it; measured number inside the range.
By their numbers in this assay, from the lowest: compound 2; then compounds 1 and 3 (each within the scatter of the next).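

In this assay, methyl(2-(piperidin-1-yl)ethyl)amino in place of bis(2-(dimethylamino)ethyl)amino on the aromatic carbon gives a number 13.7 percentage points higher from compound 2 to compound 3 (beyond the scatter), the second replacement of the bis(2-(dimethylamino)ethyl)amino group to show a number beyond the scatter of compound 2. Compound 2 therefore sits below both neighbours, while compound 1 at 28.6% and compound 3 at 30.8% lie within the scatter of each other, and among these three the only substituent without a ring is the one on compound 2, a pattern that rests on these three compounds alone and has none going against it. No measurement shown here accounts for the step.

The step changed both arms on the nitrogen at once, so the separate shares of the methyl group and the piperidine ring remain unresolved. Also open, from the compounds shown here alone, is what a pyrrolidine or morpholine ring in place of the piperidine, or a longer chain carrying that ring, would give at this aromatic carbon.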